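Lengthening the Bromoalkyl Chain on a Polybrominated Diaryl Ether

The source may hold more compounds than are shown below. What is called first, only, known or untested is meant among the compounds shown, and "the series" means these compounds.

Compound 1 `BrCCCOc1c(Br)cc(Br)cc1Oc1ccc(Br)cc1Br` in a functional assay on U-937 cells (Homo sapiens) for cytotoxicity, read by MTT assay, with a stated time of 24 h (a lower number here means a stronger inhibitor, a higher number a weaker inhibitor), gives 30.3 ug/mL.
Compound 2 `BrCCCCOc1c(Br)cc(Br)cc1Oc1ccc(Br)cc1Br` gives 29 ug/mL.
Compound 3 `COc1c(Br)cc(Br)cc1Oc1ccc(Br)cc1Br` gives 34.5 ug/mL.

Compound 2 gives the lowest of these three numbers, yet all three lie within the usual scatter of one another, so no ordering can be read from them. Compound 4 `BrCCCCCOc1c(Br)cc(Br)cc1Oc1ccc(Br)cc1Br` differs from compound 2 by bromomethyl in place of bromo on a saturated chain carbon, four bonds along the chain from an oxygen on an aromatic ring. The same kind of change, one bond nearer the ring oxygen, gave a 1.0-fold lower number from compound 1 to compound 2 (0.02 log units; within the scatter), and removing the chain entirely gave a 1.1-fold higher number from compound 1 to compound 3 (0.06 log units; within the scatter) and a 1.2-fold higher number from compound 2 to compound 3 (0.08 log units; within the scatter); none of these steps went beyond the scatter. Accordingly the step of no change at the digits printed from compound 2 to compound 4 (within the scatter) is expected to stay within the scatter as well. Compound 4 is therefore estimated at 29 ug/mL, with a range from 18 ug/mL to 46 ug/mL.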

Compound 4, half-maximal inhibitory concentration: 29.5 ug/mL
Compound 4: the middle estimate sits 1.0-fold (0.01 log units) below what was measured; the measured number falls inside the stated range.
By their numbers in this assay, from the lowest: compounds 2, 4, 1 and 3 (each within the scatter of the next).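

In this assay, extending the chain to 4-bromobutyl gives a 1.0-fold higher number from compound 2 to compound 4 (0.01 log units; within the scatter) and a 1.0-fold lower number from compound 1 to compound 4 (0.01 log units; within the scatter) and also a 1.2-fold lower number from compound 3 to compound 4 (0.07 log units; within the scatter) even though compound 3 has no bromoalkyl chain at all. So the series now shows that, at this oxygen on the aromatic ring, even the longest chain here stays within the scatter of the shorter chains and of the chainless compound. From the compounds shown here alone, whether an amine or a carboxylic acid at the chain end, or a longer chain, would leave the scatter remains open. Nothing measured here offers a reason for this result.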